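A few compounds are considered here, and "the series" means these few. Any claim that something is new, unique, unknown or untested is made for them only; others in the source may bear on it.

Measured so far in a functional assay on the whole organism (strain Wistar) for inhibition, with Rattus norvegicus as the target, read by paw edema, with stated times of 30 min and 3 h, at a dose of 200 mg/kg by the oral route; on this read-out lower numbers stand for less inhibition and higher numbers for more inhibition at the one dose given (going by the name of the read-out):

Compound 1 `COc1ccccc1-c1cc2c(n1-c1ccc(O)c(C(=O)O)c1)CCCC2` gives 50%.
Compound 2 `O=C(O)c1cc(-n2c(-c3ccc(F)cc3)cc3c2CCCC3)ccc1O` gives >= 60%; that reading is a limit of this assay, not a number.
Compound 3 `O=C(O)c1cc(-n2c(-c3ccc(O)cc3)cc3c2CCCC3)ccc1O` gives 20%.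

Compound 3 stands lowest of the two plain numbers, with compound 1 nearest and its number higher by a gap beyond the usual scatter. Compound 4 `O=C(O)c1cc(-n2c(-c3ccc([N+](=O)[O-])cc3)cc3c2CCCC3)ccc1O` differs from compound 3 in one place: nitro in place of hydroxy on an aromatic carbon. Two measured steps lead into compound 3 and so bear on this change: a number 30 percentage points lower from compound 1 to compound 3 (beyond the scatter) and a number at least 40 percentage points lower from compound 2 to compound 3 (beyond the scatter). Going by these compounds, the second rests on a limit, (the limit of >= 60% in this assay, at which 1 of the 3 values shown sits), so its true size is unknown. Both steps show that the hydroxy on this phenyl ring went with the lowest number, and that the other two groups tried there gave more inhibition. Nitro is a group not yet tried at this place, so a rise in this assay is expected, of moderate size rather than certain: a number 25 percentage points higher from compound 3 to compound 4 (beyond the scatter). Compound 4 is therefore estimated at 45%, in a range from 25% to 65%.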

Compound 4, a percentage reported as inhibition, in the whole organism at one dose (the size of the read-out at that dose, not a potency): 30%
Estimate against measurement, compound 4: 15 percentage points above, and the stated range covers the measured number.
By their numbers in this assay, from the lowest: compounds 3 and 4 (each within the scatter of the next); then compound 1. At a limit, above all of these: compound 2.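

In this assay, nitro in place of hydroxy gives a number 10 percentage points higher from compound 3 to compound 4 (within the scatter), so at this place the two groups cannot be told apart. The low reading of compound 3 is therefore not tied to hydroxy alone, since a group with no hydrogen-bond donor reads within the scatter of it, and a number 20 percentage points lower from compound 1 to compound 4 (beyond the scatter) shows that this nitro compound also falls short of the 2-methoxyphenyl compound. With fluoro at this place the gap is a number at least 30 percentage points lower from compound 2 to compound 4 (beyond the scatter), and it rests on a limit, so it gives only a floor: the limit of >= 60% in this assay, at which 1 of the 4 values shown sits.

The compounds shown leave open whether chloro or methyl at this place would read like fluoro or like the hydroxy and nitro pair. Going by these compounds, how an amine or a carboxylic acid there would read also stays open.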